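Ethyl Ester Cost Seen Once, Projected Onto Compound 4

The source may report more compounds than this note shows. Statements on the series, on what has been measured and on what is new or still open speak of the compounds shown alone.

Three related compounds have been tested in a functional assay on HT-29 cells (Homo sapiens) for cytotoxicity, read by MTT assay, with a stated time of 72 h; a higher number here means a weaker inhibitor, a lower number a stronger inhibitor. Compound 3 `COC(=O)c1sc2ccccc2c1Nc1cc(OC)c(OC)c(OC)c1` gives 299 nM there. Compound 1 `CCOC(=O)c1sc2ccccc2c1Nc1cc(OC)c(OC)c(OC)c1` carries one change from compound 3, (methyl in place of hydrogen on a saturated chain carbon bound to an oxygen next to a carbonyl group), and in this assay compound 1 gives 1610 nM, so that a 5.4-fold higher number from compound 3 to compound 1 (0.73 log units; beyond the scatter). Compound 2 `COC(=O)c1sc2ncccc2c1Nc1cc(OC)c(OC)c(OC)c1` has a different core; the difference between the two cores is not broken down here. In this assay compound 2 gives 542 nM. Compound 4 `CCOC(=O)c1sc2ncccc2c1Nc1cc(OC)c(OC)c(OC)c1` has not yet been measured; it differs from compound 2 by methyl in place of hydrogen on a saturated chain carbon bound to an oxygen next to a carbonyl group, the same change made from compound 3 to compound 1. For compound 4 a similar weakening step is expected, a 5.4-fold higher number from compound 2 to compound 4 (0.73 log units; beyond the scatter), because the same change earlier gave a 5.4-fold higher number from compound 3 to compound 1 (0.73 log units; beyond the scatter). Compound 4 is therefore estimated at 2900 nM, most likely between 1100 nM and 7500 nM, though this rests on a single earlier step.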

Compound 4, half-maximal inhibitory concentration: 2260 nM
The estimate for compound 4 lay 1.3-fold (0.11 log units) above the measured number; low and high end bracket the measured number.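

Changing methoxycarbonyl to ethoxycarbonyl on the core of compound 2 again weakens the compound in this assay, giving a 4.2-fold higher number from compound 2 to compound 4 (0.62 log units; beyond the scatter). In this series the change therefore carries from one core to the other with a step of much the same size: the same change on two cores in this assay, a 5.4-fold higher number (0.73 log units; beyond the scatter) from compound 3 to compound 1 and a 4.2-fold higher number (0.62 log units; beyond the scatter) from compound 2 to compound 4, 1.3-fold (0.11 log units) apart, within the scatter of two such steps. Among these compounds, this rests on only two pairs of compounds in a single assay, so it sets no rule for other cores and does not show why the change weakens these compounds.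

The compounds shown leave open how a longer chain such as propoxycarbonyl would read in this assay. They also leave open what a carboxylic acid or an amide in place of the ester would do.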